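Swapping fluoro for methyl on the distal ring

The source may hold more compounds than are shown below. What is called first, only, known or untested is meant among the compounds shown, and "the series" means these compounds.

Of the compounds shown here, three sharing one core have been measured in an assay for inhibition of apolipoprotein B-100 (Homo sapiens), tested at 100 nM; a lower number here means a stronger inhibitor, a higher number a weaker inhibitor. Compound 1 `COC(=O)N[C@H]1Cc2ccc(NC(=O)c3cc(C)ccc3-c3ccc(C(F)(F)F)cc3)cc2C1` gives 2.2 nM, and compound 2 `COC(=O)N[C@H]1Cc2ccc(NC(=O)c3cc(C(F)(F)F)ccc3-c3ccc(C(F)(F)F)cc3)cc2C1` gives 7.5 nM. Compound 3 `Cc1cccc(C(=O)Nc2ccc3c(c2)CC(NS(=O)(=O)c2ccccc2)C3)c1-c1ccc(F)cc1` gives 1.2 nM, the lowest of the three numbers, although its gap to compound 1 lies within the scatter, so the two cannot be ranked. Compound 4 `Cc1ccc(-c2c(C)cccc2C(=O)Nc2ccc3c(c2)CC(NS(=O)(=O)c2ccccc2)C3)cc1` differs from compound 3 by methyl in place of fluoro on an aromatic carbon. Within the data shown here, the only measured step, a 3.4-fold higher number from compound 1 to compound 2 (0.53 log units; beyond the scatter), concerns a different exchange on a different ring and so bears only loosely on this one; no measured pair shows a fluoro-to-methyl exchange. A swap of one small group for another of the same size, with no change in donors or acceptors, is expected to move this assay little, if at all. The step of a 1.3-fold higher number from compound 3 to compound 4 (0.12 log units; within the scatter) is therefore estimated to stay within the scatter. For compound 4 the expected value in this assay is 1.6 nM, with a range from 0.6 nM to 4.5 nM.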

Compound 4, half-maximal inhibitory concentration: 2.5 nM
Estimate against measurement, compound 4: 1.6-fold (0.19 log units) below; the measured number falls inside the stated range.
By their numbers in this assay, from the lowest: compounds 3, 1 and 4 (each within the scatter of the next, the first and the last beyond it); then compound 2.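

Methyl in place of fluoro, the change from 4-fluorophenyl to 4-methylphenyl, gives a 2.1-fold higher number from compound 3 to compound 4 (0.32 log units; beyond the scatter) in this assay. Among these compounds, this is the first measured exchange at this position, para to a large group, and it shows that the position responds to a change of a single heavy atom, even with no change in ring, charge, donors or acceptors. The step is modest, and the data offer no measurement that accounts for it.

On the core of compound 3, this position has been read only with fluoro and methyl, so an amine, a carboxylic acid, a methoxy group or a longer chain such as propyl could push the number either way. From the compounds shown here alone, whether the same exchange would give a similar step on the core of compound 1 also remains open.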